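Replacing 4-methoxyphenyl in a narrowly spread series

A few compounds are considered here, and "the series" means these few. Any claim that something is new, unique, unknown or untested is made for them only; others in the source may bear on it.

Compound 1 `COc1ccc(-c2c(Nc3cc(OC)c(OC)c(OC)c3)c3ccccc3oc2=O)cc1` gives 82300 nM
Compound 2 `COc1ccc(-c2c(Nc3cc(OC)c(OC)c(OC)c3)c3ccc(OC)cc3oc2=O)cc1` gives 89500 nM
Compound 3 `COc1ccc(-c2c(Nc3cc(OC)c(OC)c(OC)c3)c3ccc(O)cc3oc2=O)cc1` gives 56000 nM

All three values come from a functional assay on MCF7 cells (Homo sapiens) for antiproliferative activity, read by MTT assay, with a stated time of 48 h (a higher number here means a weaker inhibitor, a lower number a stronger inhibitor), and lie close together. Compound 2 stands level with the other two, as the steps of a 1.1-fold higher number from compound 1 to compound 2 (0.04 log units; within the scatter) and a 1.6-fold lower number from compound 2 to compound 3 (0.20 log units; within the scatter) show. The remaining step of a 1.5-fold lower number from compound 1 to compound 3 (0.17 log units; within the scatter) is equally small. Compound 4 `COc1ccc2c(Nc3cc(OC)c(OC)c(OC)c3)c(C(=O)C(F)(F)F)c(=O)oc2c1` carries (trifluoromethyl)carbonyl in place of 4-methoxyphenyl on an aromatic carbon. Among the measured compounds shown here, no measured step touches that group, so the data give no direction and only the narrow spread of values as a guide. The expected change is therefore small, with nothing beyond the scatter: a 1.8-fold lower number from compound 2 to compound 4 (0.25 log units; within the scatter) is estimated. This exchange is large, so the range stays wide. In this assay compound 4 is expected at 50000 nM (range 12000 nM to 130000 nM).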

Compound 4, half-maximal inhibitory concentration: 19200 nM
Beside the measured number, compound 4's estimate is 2.6-fold (0.42 log units) above it; the measured number falls inside the stated range.
By their numbers in this assay, from the lowest: compound 4; then compounds 3, 1 and 2 (each within the scatter of the next).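

In this assay, among the compounds shown here, replacing 4-methoxyphenyl with (trifluoromethyl)carbonyl gives a 4.7-fold lower number from compound 2 to compound 4 (0.67 log units; beyond the scatter) and is the only step in this set beyond the scatter. Unlike the earlier hydrogen, methoxy and hydroxy exchanges elsewhere on the core, it shows that the number responds to a change at this position, and that a group with no ring can stand there. Nothing available explains why the number fell. On these data alone, it remains open whether the carbonyl, the trifluoromethyl or the loss of the ring matters most; an acetyl group or a nitrile at this position could help separate these.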